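A few compounds are considered here, and "the series" means these few. Any claim that something is new, unique, unknown or untested is made for them only; others in the source may bear on it.

Measured so far in an assay on membranes from brain (Cavia porcellus) for binding affinity to Sigma non-opioid intracellular receptor 1 (Homo sapiens), read by radioligand binding; a lower number here means a stronger inhibitor, a higher number a weaker inhibitor:
compound 1, `CN(C(=N)Nc1cccc2ccccc12)c1cccc([N+](=O)[O-])c1`, gives 6260 nM
compound 2, `CN(C(=N)Nc1cccc2ccccc12)c1cccc(N)c1`, gives 2700 nM
compound 3, `CN(C(=N)Nc1cccc([N+](=O)[O-])c1)c1cccc2ccccc12`, gives 2640 nM

Compound 1 and compound 3 are built from the same atoms joined differently; the difference between the two cores is not broken down here. Compound 4, `CN(C(=N)Nc1cccc(N)c1)c1cccc2ccccc12`, has not yet been measured in this assay. The change from compound 3 to compound 4 is amino in place of nitro on an aromatic carbon. The same change, at the same kind of place, is made from compound 1 to compound 2: amino in place of nitro on an aromatic carbon. It occurs twice among the compounds shown. In this assay that step gave a 2.3-fold lower number from compound 1 to compound 2 (0.37 log units; beyond the scatter). The single earlier case is the only basis here. Because the same change on the core of compound 1 gave a 2.3-fold lower number from compound 1 to compound 2 (0.37 log units; beyond the scatter), the step expected for compound 4 is a 2.2-fold lower number from compound 3 to compound 4 (0.34 log units; beyond the scatter). For compound 4 the estimated value in this assay is 1200 nM, with a likely range from 500 nM to 3000 nM.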

Compound 4, half-maximal inhibitory concentration: 13000 nM
Compound 4: the middle estimate sits 11-fold (1.03 log units) below what was measured; the measured number lies above the stated range.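

In this assay, amino in place of nitro on an aromatic carbon gave a 4.9-fold higher number from compound 3 to compound 4 (0.69 log units; beyond the scatter), so the step did not keep its direction from one core to the other: the same change on two cores in this assay, a 2.3-fold lower number (0.37 log units; beyond the scatter) from compound 1 to compound 2 and a 4.9-fold higher number (0.69 log units; beyond the scatter) from compound 3 to compound 4, 11-fold (1.06 log units) apart, beyond the scatter of two such steps. In this series, the outcome of this change therefore depends on the core it is made on, and a step measured on one core cannot simply be transferred to the other. The two steps do not show which difference between the cores is responsible, nor do they give a rule for any further core.

Still open, on these data alone, is how a methoxy group or a carboxylic acid on the same aromatic carbon would behave on each core. Also open, as far as these compounds go, is whether a longer chain in place of the methyl group would preserve the split.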